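A few compounds are considered here, and "the series" means these few. Any claim that something is new, unique, unknown or untested is made for them only; others in the source may bear on it.

Working notes on the series. Going by the values given here, compound 2 `N#Cc1cccc(/C(CCN2CCN(c3ccccn3)CC2)=N/O)c1` stands, in a functional assay on HEK293 cells with D(4) dopamine receptor (Homo sapiens) as the target, read by FLIPR (on this read-out higher numbers stand for an effect only at larger amounts of compound and lower numbers for an effect already at smaller amounts), at 13.1 nM, the highest of the two numbers measured so far; its nearest neighbour is compound 1 `Cc1ccccc1/C(CCN1CCN(c2ccccn2)CC1)=N/O`, which in this assay gives 4.2 nM. Among the compounds with values here, the one measured step, a 3.1-fold higher number from compound 1 to compound 2 (0.49 log units; beyond the scatter), is the only comparison that bears on the next change, since both steps alter the aryl group on the same carbon with a double bond to nitrogen. Compound 3 `O/N=C(\CCN1CCN(c2ccccn2)CC1)c1ccc(F)cc1F` differs from compound 2 as follows: 2,4-difluorophenyl in place of 3-cyanophenyl on a carbon with a double bond to nitrogen. With one modest step in hand, a change of similar size is plausible, and as compound 1 with 2-methylphenyl gave the lower number 4.2 nM, a drift back toward that value is the working expectation. For compound 3 in this assay the estimated step is a 1.9-fold lower number from compound 2 to compound 3 (0.27 log units; within the scatter). The estimated value for compound 3 is 7 nM, expected within 2.5 nM to 20 nM.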

Compound 3, half-maximal effective concentration: 8.9 nM
Compound 3: the middle estimate sits 1.3-fold (0.10 log units) below what was measured; low and high end bracket the measured number.
By their numbers in this assay, from the lowest: compound 1; then compounds 3 and 2 (each within the scatter of the next).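

In this assay, the step of a 1.5-fold lower number from compound 2 to compound 3 (0.17 log units; within the scatter) shows that 2,4-difluorophenyl and 3-cyanophenyl on this carbon with a double bond to nitrogen cannot be told apart, although one group carries two fluorine atoms and the other a nitrile. The second comparison, a 2.1-fold higher number from compound 1 to compound 3 (0.33 log units; beyond the scatter), is a modest one and adds a second aryl group that separates from 2-methylphenyl. Going by these compounds alone, of the three compounds, compound 1 is therefore the only one whose steps to both others lie beyond the scatter, so it has the lowest number, while the range across all three aryl groups remains narrow.

As far as these compounds go, whether an aryl group carrying an amine or a carboxylic acid, or a saturated ring such as cyclohexyl, would stay within this narrow range on the same carbon remains open. Nothing at hand accounts for the position of 2-methylphenyl relative to the other two groups.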